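A few compounds are considered here, and "the series" means these few. Any claim that something is new, unique, unknown or untested is made for them only; others in the source may bear on it.

Measured in a functional assay on MCF7 cells (Homo sapiens) for cytotoxicity, read by MTT assay, with a stated time of 72 h; a lower number here means a stronger inhibitor, a higher number a weaker inhibitor:
- Compound 1 `CNC(=O)c1cc(Oc2ccc(NC(=O)c3nccc(-c4ccccc4)n3)cc2)ccn1`: 39100 nM
- Compound 2 `CNC(=O)c1cc(Oc2ccc(NC(=O)c3cc(-c4ccc(C)cc4)ncn3)cc2)ccn1`: 34600 nM
- Compound 3 `CNC(=O)c1cc(Oc2ccc(NC(=O)c3cc(-c4ccc(C(F)(F)F)cc4)ncn3)cc2F)ccn1`: > 100000 nM (a limit of the assay, not a number)

In this assay, compound 2 gives 34600 nM and compound 1 gives 39100 nM. These two values lie within the usual scatter of each other, so they cannot be ranked. Compound 3 stands at a limit of the assay, as the limit of > 100000 nM in this assay, at which 1 of the 3 values shown sits, records, and gives no number for comparison.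

Compound 4 `CNC(=O)c1cc(Oc2ccc(NC(=O)c3cc(-c4ccccc4)ncn3)cc2)ccn1` has not yet been measured. It differs from compound 2 by hydrogen in place of methyl on an aromatic carbon, para to a large group, which turns 4-methylphenyl into phenyl (hydrogen in place of methyl on an aromatic carbon). Within the data shown here, no measured pair shows this change, so the expectation rests on compound 2 at 34600 nM and on the small size of the change. No shift beyond the scatter is expected, and the estimated step is a 1.1-fold higher number from compound 2 to compound 4 (0.04 log units; within the scatter). For compound 4 the expected value is 38000 nM, with an estimated range of 16000 nM to 90000 nM.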

Compound 4, half-maximal inhibitory concentration: 18200 nM
Beside the measured number, compound 4's estimate is 2.1-fold (0.32 log units) above it; measured number inside the range.
By their numbers in this assay, from the lowest: compounds 4, 2 and 1 (each within the scatter of the next, the first and the last beyond it). At a limit, above all of these: compound 3.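

In this assay, compounds 2 and 4 form the only pair shown that differs in one place, and going from 4-methylphenyl to phenyl gives a 1.9-fold lower number from compound 2 to compound 4 (0.28 log units; within the scatter). On this aromatic carbon, para to a large group, the methyl can thus give way to hydrogen without a shift beyond the usual scatter, so compound 2 and compound 4 cannot be ranked, and neither group stands out at this position. Nothing measured here bears on a cause for this small step.

On these data alone, what a methoxy group, a chlorine atom or an amine would do at this place remains open. Trifluoromethyl at this place cannot be read on its own: it comes with a second difference in the structure, and compound 3 gives > 100000 nM, a limit of the assay and not a number.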